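The compounds below may be only part of what the source reports. "The series", "measured", "known", "first", "only" and "open" are said of these compounds alone.

Compound 1, with the structure `CC(C)=CCCC(=O)[C@]1(/C=C/C(C)C)C[C@H](CC=C(C)C)C(C)(C)[C@H](C(=O)c2ccccc2)C1=O`, and compound 2, with the structure `CC(C)=CC[C@@H]1C[C@H](CC=C(C)C)C(C)(C)[C@H](C(=O)C(C)C)C1=O`, were both tested in a functional assay on 786-0 cells (Homo sapiens) for cytotoxicity, read by CellTiter-Glo, with a stated time of 5 days; a higher number here means a weaker inhibitor, a lower number a stronger inhibitor. In this assay compound 1 gives > 10000 nM, which is a limit of the assay and not a number. In this assay compound 2 likewise gives > 10000 nM, again a limit rather than a measured number. Every value so far therefore sits at the limit of > 10000 nM in this assay, at which 2 of the 2 values shown sit, so compound 2 stands nowhere in particular among the numbers shown: no compound in this set has yet produced a measurable potency, and no step between measured compounds is available.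

Compound 3, with the structure `CC(C)=CC[C@@H]1C[C@H](CC=C(C)C)C(C)(C)[C@@H](C(=O)C(C)C)C1=O`, is the next compound. It differs from compound 2 as follows: the two compounds have the same atoms and bonds and differ only in configuration as drawn: 1 of 3 stereo elements differ; a stereocentre at a saturated ring carbon is drawn R in compound 2 and S in compound 3. With both measured compounds sitting at the limit, the step from compound 2 to compound 3 is expected to be none beyond the scatter, as expressed by a number no higher from compound 2 to compound 3 (the limit leaves the size open). Compound 3 is accordingly expected to give 10000 nM in this assay, within a range from 3000 nM to 30000 nM.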

Compound 3, half-maximal inhibitory concentration: > 10000 nM
Compound 3 ended at the assay's limit (the forecaster's own chance of this, stated with the estimate: 80%); the middle value sits exactly at the limit.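

In this assay compound 3 gives > 10000 nM, a limit of the assay and not a number. No step can be read between compound 2 and compound 3. The compounds shown leave open whether the configuration at that saturated ring carbon matters for potency in this assay.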